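The source may hold more compounds than are shown below. What is called first, only, known or untested is meant among the compounds shown, and "the series" means these compounds.

Working notes on the series. Compound 1 `CN(C)CCCn1c(Cc2nn(C)c(=O)c3ccccc23)nnc1SCCCCCCCC(=O)Nc1ccc(Cl)cc1Cl` and compound 2 `Cn1nc(Cc2nnc(SCCCCCCCC(=O)Nc3ccc(Cl)cc3Cl)n2CCCO)c2ccccc2c1=O` share one core and differ in a single place: hydroxy in place of dimethylamino on a saturated chain carbon, three bonds along the chain from an aromatic nitrogen. In an assay on NK92 cells for inhibition of interleukin-15 (Homo sapiens), read by AlphaScreen, with stated times of 30 min and 1 h (a higher number here means a weaker inhibitor, a lower number a stronger inhibitor), compound 1 gives > 30000 nM, which is a limit of the assay and not a number. Compound 2 gives > 30000 nM in this assay, again a limit of the assay rather than a number. The step that the two limits leave unreadable from compound 1 to compound 2 therefore has no readable size. Compound 3 `CN(C)CCCn1nc(Cc2nnc(SCCCCCCCC(=O)Nc3ccc(Cl)cc3Cl)n2C)c2ccccc2c1=O` is built from the same atoms as compound 1 joined differently, and the difference between the two cores is not broken down here. In this assay compound 3 gives > 30000 nM, also a limit of the assay and not a number. All that is in hand for the three measured compounds is the limit of > 30000 nM in this assay, at which 3 of the 3 values shown sit.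

Compound 4 `Cn1c(Cc2nn(CCCO)c(=O)c3ccccc23)nnc1SCCCCCCCC(=O)Nc1ccc(Cl)cc1Cl` is not yet measured in this assay. It differs from compound 3 by hydroxy in place of dimethylamino on a saturated chain carbon, three bonds along the chain from an aromatic nitrogen, the same change as from compound 1 to compound 2, at the same place. The ground for any expectation is the limit of > 30000 nM in this assay, at which 3 of the 3 values shown sit, on which compound 1, compound 2 and compound 3 all sit. The step that the limit leaves unreadable from compound 3 to compound 4 is expected to be small and most likely to remain unreadable. Compound 4 is expected to come back as a limit again, with an estimate in this assay of 50000 nM, between 15000 nM and 200000 nM.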

Compound 4, half-maximal inhibitory concentration: > 30000 nM
Compound 4: only a limit was reported; the forecaster's own chance of this, stated with the estimate: 85%; the middle value does not contradict the limit.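

In this assay compound 4 gives > 30000 nM, a limit of the assay and not a number, so no size can be read for the step between compound 3 and compound 4. The compounds shown leave open whether hydroxy in place of dimethylamino has any effect at all, and whether any member of this series gives a measurable value: the limit of > 30000 nM in this assay, at which 4 of the 4 values shown sit.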